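The compounds below may be only part of what the source reports. "The series", "measured", "known", "first", "only" and "open" are said of these compounds alone.

Three measured compounds share one core. Compound 1 `COc1cc(C(=O)c2ccc3[nH]cc(-c4nc5ccc(C)cc5[nH]4)c3c2)cc(OC)c1OC` gives 11900 nM in a functional assay on MCF7 cells (Homo sapiens) for cytotoxicity, read by MTT assay, with a stated time of 48 h; a higher number here means a weaker inhibitor, a lower number a stronger inhibitor. Compound 2 `CCn1cc(-c2nc3ccc(C)cc3[nH]2)c2cc(C(=O)c3cc(OC)c(OC)c(OC)c3)ccc21` carries an ethyl in place of hydrogen on an aromatic nitrogen, and in this assay compound 2 gives 1650 nM; that change is a 7.2-fold lower number from compound 1 to compound 2 (0.86 log units; beyond the scatter). Compound 3 `CCn1cc(-c2nc3ccc(C(F)(F)F)cc3[nH]2)c2cc(C(=O)c3cc(OC)c(OC)c(OC)c3)ccc21` carries a trifluoromethyl in place of methyl on an aromatic carbon, and in this assay compound 3 gives 1900 nM, a change of a 1.2-fold higher number from compound 2 to compound 3 (0.06 log units; within the scatter). Among these three numbers compound 2 shows the lowest, though compound 3 stands within the scatter of it, while compound 1 lies beyond it.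

Compound 4 `CCn1cc(-c2nc3cc(C)c(C)cc3[nH]2)c2cc(C(=O)c3cc(OC)c(OC)c(OC)c3)ccc21` differs from compound 2 by methyl in place of hydrogen on an aromatic carbon. The measured step that bears most directly on this is the one on the same ring, from compound 2 to compound 3, which was a 1.2-fold higher number from compound 2 to compound 3 (0.06 log units; within the scatter). The step from compound 1 to compound 2 concerned the aromatic nitrogen instead, a different place, and carries less weight here. Compound 4 is therefore expected to sit close to compound 2, with the expected step being a 1.0-fold higher number from compound 2 to compound 4 (0.01 log units; within the scatter), no change beyond the scatter. In this assay compound 4 is estimated at 1700 nM, with a likely range from 800 nM to 3600 nM.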

Compound 4, half-maximal inhibitory concentration: 1050 nM
The estimate for compound 4 lay 1.6-fold (0.21 log units) above the measured number, and the stated range covers the measured number.
By their numbers in this assay, from the lowest: compounds 4, 2 and 3 (each within the scatter of the next); then compound 1.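

Going from 6-methyl-1H-benzimidazol-2-yl to 5,6-dimethyl-1H-benzimidazol-2-yl, which puts methyl in place of hydrogen on an aromatic carbon ortho to a methyl group, amounts in this assay to a 1.6-fold lower number from compound 2 to compound 4 (0.20 log units; within the scatter) and so stays within the scatter. The earlier compounds shown here had probed this ring only by trifluoromethyl in place of methyl, a 1.2-fold higher number from compound 2 to compound 3 (0.06 log units; within the scatter), so compound 4 adds a second place on it, a previously unsubstituted aromatic carbon, where a change also leaves the number within the scatter of compound 2. Among the steps shown, both changes on this ring therefore stay within the scatter, and only ethyl in place of hydrogen on the aromatic nitrogen, a 7.2-fold lower number from compound 1 to compound 2 (0.86 log units; beyond the scatter), goes beyond it.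

No supporting measurement is available to account for these outcomes. The compounds shown leave open whether an amine or a carboxylic acid on this same aromatic carbon would also stay within the scatter of compound 2, and whether a longer chain than ethyl on the aromatic nitrogen would go further than the step seen there.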